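Three Aryl Swaps, One Maximal Response, a Fourth to Come

A few compounds are considered here, and "the series" means these few. Any claim that something is new, unique, unknown or untested is made for them only; others in the source may bear on it.

Three measured compounds share one core and differ only in the aromatic group attached to it. Compound 1 `O=C(O)Cc1sc(C(c2ccc(F)cc2)c2ccc(F)cc2)nc1-c1ccnc(N2CCCC2)c1` carries a 2-(pyrrolidin-1-yl)pyridin-4-yl group, and in an in vitro functional assay on HEK285-7 cells for antagonist activity at prostaglandin D2 receptor 2 (Homo sapiens), read by BRET and beta-arrestin recruitment (on this read-out higher numbers stand for larger maximal responses and lower numbers for smaller maximal responses), compound 1 reaches 80%. Compound 2 `O=C(O)Cc1sc(C(c2ccc(F)cc2)c2ccc(F)cc2)nc1-c1ccc(Cl)cc1` carries a 4-chlorophenyl group in that place, and in this assay compound 2 reaches 80%. Compound 3 `CS(=O)(=O)Nc1cccc(-c2nc(C(c3ccc(F)cc3)c3ccc(F)cc3)sc2CC(=O)O)c1` carries a 3-(methanesulfonamido)phenyl group, and in this assay compound 3 reaches 80%. The steps between them are no change at the digits printed from compound 1 to compound 2 (within the scatter), no change at the digits printed from compound 1 to compound 3 (within the scatter) and no change at the digits printed from compound 2 to compound 3 (within the scatter), so compound 3 stands level with compounds 1 and 2 on this read-out.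

Compound 4 `N#Cc1ccc(-c2nc(C(c3ccc(F)cc3)c3ccc(F)cc3)sc2CC(=O)O)cc1` is the next variation at the same position: 4-cyanophenyl in place of 3-(methanesulfonamido)phenyl on an aromatic carbon. All three measured steps bear on it, since each one exchanges the aromatic group at this same place on the core, and each stayed within the usual scatter. Three exchanges of quite different groups without any shift give no ground to expect a fourth exchange to move the maximal response, so the expected step in this assay is no change at the digits printed from compound 3 to compound 4 (within the scatter), none beyond the scatter. Compound 4 is therefore estimated to reach 80% in this assay, with a range from 65% to 95%.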

Compound 4, largest response reached (reported as efficacy), in percent of the reference or control that the assay uses: 30%
Compound 4: the middle estimate sits 50 percentage points above what was measured, outside the stated range (below it).
By their numbers in this assay, from the lowest: compound 4; then compounds 1, 2 and 3 (each within the scatter of the next).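

This result shows that the position is not indifferent to what it carries, as the three earlier compounds might have suggested. The clearest comparison in this assay is the exchange of chloro for cyano on an otherwise unchanged phenyl ring, which gives a number 50 percentage points lower from compound 2 to compound 4 (beyond the scatter), so a change of a single substituent is enough to separate two compounds that share everything else. The two larger exchanges agree with it, giving a number 50 percentage points lower from compound 3 to compound 4 (beyond the scatter) and a number 50 percentage points lower from compound 1 to compound 4 (beyond the scatter), and so compound 4 stands apart from all three earlier compounds, although no measurement here explains why the maximal response falls with the 4-cyanophenyl group.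

The compounds shown leave open whether this fall belongs to the cyano group alone or would also appear with other groups at that place on the phenyl ring, such as a methoxy group, an amine or a carboxylic acid. They also leave open whether the cyano group must stand where it does in the 4-cyanophenyl group, a question that a 3-cyanophenyl group at the same place on the core would address.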